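The source may hold more compounds than are shown below. What is called first, only, known or untested is meant among the compounds shown, and "the series" means these compounds.

Measured so far:
compound 1, `CC[S+]([O-])c1nnc(-c2ccccc2)n1C`: 14.4 mg/kg
compound 2, `CC[S+]([O-])c1nnc(-c2ccccc2F)n1C`: 32.7 mg/kg
compound 3, `Cn1nc(-c2ccccc2)nc1S(C)(=O)=O`: > 200 mg/kg

In a functional assay on the whole organism for antagonist activity, with Mus musculus as the target (on this read-out lower numbers stand for an effect already at smaller amounts and higher numbers for an effect only at larger amounts of compound), compound 1 gives 14.4 mg/kg. Compound 2 differs from it by fluoro in place of hydrogen on an aromatic carbon, and in this assay compound 2 gives 32.7 mg/kg, a step of a 2.3-fold higher number from compound 1 to compound 2 (0.36 log units; beyond the scatter). For compound 3 this assay reports only a limit, > 200 mg/kg. The difference between the core of compound 1 and the core of compound 3 is not broken down here.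

Compound 4, `Cn1nc(-c2cccc(F)c2)nc1S(C)(=O)=O`, has not yet been measured. It differs from compound 3 by fluoro in place of hydrogen on an aromatic carbon. For the measured compounds named here, this is the same kind of change as the one from compound 1 to compound 2, not the same: there the fluoro enters ortho to a large group, here meta to a large group. Compound 3 already sits at the limit of > 200 mg/kg in this assay, at which 1 of the 3 values shown sits. Going by the values given here, the only measured step of this kind is modest, so the expected step is a step that the limit leaves unreadable from compound 3 to compound 4, and compound 4 is estimated at 300 mg/kg, most likely again only a limit.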

Compound 4, dose for half-maximal effect: > 100 mg/kg
Compound 4: a limit, no number; the forecaster's own chance of this, stated with the estimate: 80%; the middle value lies beyond the limit too.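

In this assay, for the compounds shown here, compound 3 and compound 4 each appear only as a limit, and no step between them can be read. The compounds shown leave open whether fluoro in place of hydrogen changes anything on the core of compound 3.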